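Swapping the phenol side of a chalcone for trimethoxyphenyl

A few compounds are considered here, and "the series" means these few. Any claim that something is new, unique, unknown or untested is made for them only; others in the source may bear on it.

Measured compounds:
- compound 1, `COc1cc(/C=C/C(=O)c2cccc(-n3cc(-c4ccc(Cl)cc4)[nH]c3=O)c2)cc(OC)c1OC`: 24300 nM
- compound 2, `COc1ccc(-c2cn(-c3cccc(C(=O)/C=C/c4ccc(O)c(OC)c4)c3)c(=O)[nH]2)cc1`: 13900 nM

Both compounds share a core in which a chalcone-type chain links two aromatic parts, and both were tested in a functional assay on SF-295 cells (Homo sapiens) for inhibition; on this read-out lower numbers stand for stronger inhibition of growth and higher numbers for weaker inhibition of growth. In that assay compound 1 gives 24300 nM, while compound 2 gives 13900 nM. The two numbers sit within the usual scatter of each other, so neither compound stands apart from the other on this read-out; the data simply show two weak growth inhibitors of similar standing.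

Compound 3, `COc1ccc(-c2cn(-c3cccc(C(=O)/C=C/c4cc(OC)c(OC)c(OC)c4)c3)c(=O)[nH]2)cc1`, has not been measured. It differs from compound 2 in one place: 3,4,5-trimethoxyphenyl in place of 4-hydroxy-3-methoxyphenyl on a double-bonded chain carbon bound to a double-bonded chain carbon. Among the measured compounds shown here, the same trimethoxyphenyl group is already present in compound 1, though on a differently substituted core, so no step between measured compounds isolates this change.

The expectation is that this swap changes little in this assay, with at most a small weakening that stays close to the scatter, an expected step of a 1.4-fold higher number from compound 2 to compound 3 (0.16 log units; within the scatter). Compound 3 is therefore estimated at 20000 nM, with a likely range from 8000 nM to 50000 nM.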

Compound 3, concentration for 50% growth inhibition: 4950 nM
Compound 3: middle estimate off by 4.0-fold (0.61 log units), on the high side, outside the stated range (below it).
By their numbers in this assay, from the lowest: compound 3; then compounds 2 and 1 (each within the scatter of the next).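

In this assay, 3,4,5-trimethoxyphenyl in place of 4-hydroxy-3-methoxyphenyl on a double-bonded chain carbon bound to a double-bonded chain carbon gives a 2.8-fold lower number from compound 2 to compound 3 (0.45 log units; beyond the scatter), which shows that this position responds to the swap, modestly but beyond the usual scatter. With that trimethoxyphenyl group held constant, methoxy in place of chloro on an aromatic carbon gives a 4.9-fold lower number from compound 1 to compound 3 (0.69 log units; beyond the scatter), so the other end of the molecule also affects the read-out, again by a modest step beyond the scatter. Compounds 1 and 2 differ in two places at once, so they could not show either of these effects separately, whereas compound 3 differs from each of them in only one place.

No measurement here explains why either change lowers the number. Still open, going by these compounds, is whether the step at the chain end follows from losing the hydroxy group or from gaining methoxy groups, and how this position would respond to a phenyl ring carrying a dimethylamino group or a carboxylic acid instead.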